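A few compounds are considered here, and "the series" means these few. Any claim that something is new, unique, unknown or untested is made for them only; others in the source may bear on it.

Working notes on the series in a functional assay on A549 cells (Homo sapiens) for inhibition, read by sulforhodamine B assay, with a stated time of 48 h; a higher number here means a weaker inhibitor of growth, a lower number a stronger inhibitor of growth. Compound 1 `Nc1cc(N)c2nc(-c3ccccc3)c(NCc3ccc(Cl)c(Cl)c3)nc2c1` gives 10700 nM; compound 2 `COc1ccc(CNc2nc3cc(N)cc(N)c3nc2-c2ccccc2)cc1OC` gives 20900 nM; compound 3 `Nc1cc(N)c2nc(-c3ccccc3)c(NCc3ccc(F)cc3)nc2c1` gives 17800 nM, the second highest of the three numbers, nearest compound 2. All three steps among them, a 2.0-fold higher number from compound 1 to compound 2 (0.29 log units; within the scatter), a 1.7-fold higher number from compound 1 to compound 3 (0.22 log units; within the scatter) and a 1.2-fold lower number from compound 2 to compound 3 (0.07 log units; within the scatter), stay within the scatter, so the benzyl substituent has so far not moved the read-out. Compound 4 `COc1ccc(CNc2nc3cc(N)cc(N)c3nc2-c2ccccc2)cc1` carries a change of methoxy in place of fluoro on an aromatic carbon. The step from compound 2 to compound 3 bears most on it, exchanging a dimethoxy for a fluoro pattern without effect beyond the scatter, and the dichloro variant agrees. Compound 4 is therefore expected to show a 1.1-fold higher number from compound 3 to compound 4 (0.03 log units; within the scatter), no shift beyond the scatter. Compound 4 is estimated at 19000 nM, within 9000 nM to 40000 nM.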

Compound 4, concentration for 50% growth inhibition: 21400 nM
Compound 4: the middle estimate sits 1.1-fold (0.05 log units) below what was measured; the measured number falls inside the stated range.
By their numbers in this assay, from the lowest: compounds 1, 3, 2 and 4 (each within the scatter of the next).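

Methoxy in place of fluoro on an aromatic carbon para to a large group is a single-group exchange at this position, and it stays within the scatter (a 1.2-fold higher number from compound 3 to compound 4 (0.08 log units; within the scatter)). Hydrogen in place of methoxy on an aromatic carbon (a 1.0-fold higher number from compound 2 to compound 4 (0.01 log units; within the scatter)) and 4-methoxyphenyl in place of 3,4-dichlorophenyl (a 2.0-fold higher number from compound 1 to compound 4 (0.30 log units; within the scatter)) also stay within it, so all four benzyl variants remain within the scatter of one another. No supporting data bear on this result. On these data alone, whether an amine or a carboxylic acid on this aromatic carbon would shift the number beyond the scatter remains open. The same applies to a longer chain between the aromatic ring and the nitrogen.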